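Chloro added to the fluorophenyl of compound 2

This account rests on a few compounds, and the source may have more. Where it says the series, first, only, none or still open, it means among the compounds named here.

Working notes on a small set measured in an assay on isolated protein for displacement of a labelled ligand from metabotropic glutamate receptor 5 (Homo sapiens), with a stated time of 60 min, tested at 1 uM; on this read-out higher numbers stand for more inhibition at the one concentration tested (going by the name of the read-out) and lower numbers for less inhibition. Compound 1 `CC1CCN(c2c(S(=O)(=O)c3ccccc3)cnc3ccc(F)cc23)CC1` gives 40% in this assay. Among the compounds with values here, compound 3 `CC1CCN(c2c(S(=O)(=O)c3ccccc3)cnc3ccc(Cl)cc23)CC1` gives 59%, and the one single-point step in the set, a number 19 percentage points higher from compound 1 to compound 3 (beyond the scatter), runs upward. Compound 2 `CC1CCN(c2c(S(=O)(=O)c3ccc(F)cc3)cnc3cc(Cl)ccc23)CC1` gives 91%; it stands highest of the three numbers, its gap to compound 3 and its gap to compound 1 both beyond the scatter, so on these numbers compound 2 has the highest inhibition in this assay of the set.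

Compound 4 `CC1CCN(c2c(S(=O)(=O)c3ccc(F)c(Cl)c3)cnc3cc(Cl)ccc23)CC1` has not yet been measured. It differs from compound 2 by chloro in place of hydrogen on an aromatic carbon. Within the data shown here, no measured pair reports this particular change on the 4-fluorophenyl; the only step available, the chloro-for-fluoro step on the core from compound 1 to compound 3, is modest and upward, and no step in the set runs downward. Compound 2 already sits close to the top of the read-out, which leaves little room for a further rise. The step from compound 2 to compound 4 is therefore expected to be a number 1 percentage points lower from compound 2 to compound 4 (within the scatter), that is, none beyond the scatter. Compound 4 is estimated at 90%, within a range from 76% to 99%.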

Compound 4, a percentage reported as inhibition, at one concentration (the size of the read-out at that concentration, not a potency): 94%
Beside the measured number, compound 4's estimate is 4 percentage points below it; the range from low to high includes it.
By their numbers in this assay, from the lowest: compound 1; then compound 3; then compounds 2 and 4 (each within the scatter of the next).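

In this assay, going from 4-fluorophenyl to 3-chloro-4-fluorophenyl gives a number 3 percentage points higher from compound 2 to compound 4 (within the scatter), so this position on the fluorophenyl accepts a chloro ortho to a fluoro group with no change beyond the scatter, a reading the earlier chloro-for-fluoro step on the core could not give. Compound 2 at 91% and compound 4 at 94% both lie close to the top of this single-concentration read-out, so the pair cannot show whether the added chloro changes potency in either direction. Nothing available explains why the number holds at this position.

Still open, going by these compounds, is whether a concentration-response measurement would separate compound 2 from compound 4, since inhibition at one concentration leaves little room at this level. Also open, on these data alone, is how far this position extends beyond chloro: a methoxy, a nitrile, an amine or a carboxylic acid there would show whether the position accepts groups other than a single halogen atom.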